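The source may report more compounds than this note shows. Statements on the series, on what has been measured and on what is new or still open speak of the compounds shown alone.

The series shares one core and varies only the aryl group on the sulfonyl sulfur. Compound 1 `COc1ccc(-c2cc(=O)c3c(OC)cc(OC)cc3n2S(=O)(=O)c2ccc(C=O)cc2)cc1` carries a 4-formylphenyl there. In a functional assay on KOPN-8 cells (Homo sapiens) for antiproliferative activity, with a stated time of 72 h (a higher number here means that more compound is needed for the effect, a lower number that less compound is needed), compound 1 gives only a limit, > 34400 nM. Compound 2 `COc1ccc(-c2cc(=O)c3c(OC)cc(OC)cc3n2S(=O)(=O)c2ccc(C)c([N+](=O)[O-])c2)cc1` carries a 4-methyl-3-nitrophenyl instead, and in this assay compound 2 likewise gives only a limit, > 51700 nM. Compound 3 `COc1ccc(-c2cc(=O)c3c(OC)cc(OC)cc3n2S(=O)(=O)c2c(F)c(F)c(F)c(F)c2F)cc1` carries a 2,3,4,5,6-pentafluorophenyl, and in this assay compound 3 again gives only a limit, > 34400 nM.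

Within the data shown here, none of the measured steps can be read: a step that the two limits leave unreadable from compound 1 to compound 2, a step that the two limits leave unreadable from compound 1 to compound 3 and a step that the two limits leave unreadable from compound 2 to compound 3 all run between limits. Two limits cover all three values, namely the limit of > 34400 nM in this assay, at which 2 of the 3 values shown sit, and (the limit of > 51700 nM in this assay, at which 1 of the 3 values shown sits); compound 3 therefore stands at a limit, as do the two other compounds, and no ordering among the three can be claimed.

Compound 4 `COc1ccc(-c2cc(=O)c3c(OC)cc(OC)cc3n2S(=O)(=O)c2ccc(OC)cc2)cc1` differs from compound 3 by 4-methoxyphenyl in place of 2,3,4,5,6-pentafluorophenyl on a sulfonyl sulfur. Every measured step touching this position is unreadable, so no direction or size can be taken from them. Given that compound 3 sits at > 34400 nM, the step from compound 3 to compound 4 in this assay is expected to be a step that the limit leaves unreadable from compound 3 to compound 4, most likely again ending in a limit. Compound 4 is estimated in this assay at 40000 nM, within a range from 8000 nM to 200000 nM.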

Compound 4, half-maximal effective concentration: > 82700 nM
Compound 4: only a limit was reported (the forecaster's own chance of this, stated with the estimate: 80%); middle value at least 2.0-fold (0.31 log units) from the limit.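

Compound 4, like compound 1, compound 2 and compound 3, gives only a limit in this assay, so the steps from each of those three compounds to compound 4 cannot be read. The compounds shown leave open how the four aryl groups on the sulfonyl sulfur rank against one another, and at what concentration any of them reaches the half-maximal effect.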